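Isopropylsulfonyl to Isopropylsulfamoyl on the Aryl Sulfonyl Group

A few compounds are considered here, and "the series" means these few. Any claim that something is new, unique, unknown or untested is made for them only; others in the source may bear on it.

Measured so far:
compound 1 `CC(C)c1noc(N2CCN(C(=O)[C@@H]3CCCN(S(=O)(=O)c4ccc(S(=O)(=O)C5CCC5)cc4)C3)CC2)n1` — 20 nM
compound 2 `CC(C)c1noc(N2CCN(C(=O)[C@@H]3CCCN(S(=O)(=O)c4ccc(S(=O)(=O)C(C)C)cc4)C3)CC2)n1` — 30 nM

Of the compounds shown here, two have been measured in a functional assay on MIA PaCa-2 cells (Homo sapiens) for inhibition, read by MTT assay, with a stated time of 3 days; a higher number here means a weaker inhibitor, a lower number a stronger inhibitor. Compound 1 gives 20 nM, and compound 2 gives 30 nM. Compound 2 holds the higher of the two numbers, but the step of a 1.5-fold higher number from compound 1 to compound 2 (0.18 log units; within the scatter) lies within the scatter, so the two compounds cannot be told apart on these data.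

Compound 3 `CC(C)NS(=O)(=O)c1ccc(S(=O)(=O)N2CCC[C@@H](C(=O)N3CCN(c4nc(C(C)C)no4)CC3)C2)cc1` has not yet been measured. It differs from compound 2 in one place: isopropylamino in place of isopropyl on a sulfonyl sulfur. Within the data shown here, the only measured step, from cyclobutyl to isopropyl on the same sulfonyl sulfur, exchanges one carbon-only group for another and brings in no nitrogen, so it does not bear directly on the arrival of an isopropylamino group. Among the measured compounds shown here, no measured step speaks to this change; the expectation therefore rests on the modest spread seen so far. For compound 3 a number in the same region is expected, estimated at 40 nM with a range from 15 nM to 120 nM. The step of a 1.3-fold higher number from compound 2 to compound 3 (0.12 log units; within the scatter) is expected to stay within the scatter, and the range is kept wide to reflect the lack of a guiding step.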

Compound 3, half-maximal inhibitory concentration: 200 nM
For compound 3 the middle estimate is 5.0-fold (0.70 log units) below the measured one; the measured number lies above the stated range.
By their numbers in this assay, from the lowest: compounds 1 and 2 (each within the scatter of the next); then compound 3.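

Among these compounds, on the sulfonyl sulfur, whose other neighbour is an aromatic carbon, exchanging one carbon-only group for another had left the number within the scatter, but the isopropylamino group does not behave in that way: in this assay, placing it in the position of isopropyl gives a 6.7-fold higher number from compound 2 to compound 3 (0.82 log units; beyond the scatter) and is the first change here to move the number beyond the scatter. Placing it in the position of cyclobutyl gives a 10-fold higher number from compound 1 to compound 3 (1.00 log units; beyond the scatter) and makes compound 3 the weakest inhibitor of the three, so this position responds to the change from a carbon-attached group to one attached through a nitrogen that carries a hydrogen-bond donor, at least in these compounds. No measurement available here accounts for this difference.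

The compounds shown leave open whether the higher number follows the nitrogen itself or the hydrogen on it, a question that a dimethylamino group on the same sulfur would help to separate. They also leave open whether a cyclobutylamino group would show a similar step from its carbon-attached counterpart.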